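From a Nitro Group to a Hydroxyl: Compound 4 Awaits Measurement

The source may report more compounds than this note shows. Statements on the series, on what has been measured and on what is new or still open speak of the compounds shown alone.

Measured in a functional assay on SW-620 cells (Homo sapiens) for antiproliferative activity, read by MTT assay, with a stated time of 24 h; a lower number here means a stronger inhibitor, a higher number a weaker inhibitor:
- compound 1, `COc1ccc(C(=O)/C=C/c2ccc(N3CCCC3)cc2)c2c1C=CC(C)(C)O2`: compound 1 gives 7150 nM
- compound 2, `COc1ccc(C(=O)/C=C/c2ccc3ccccc3n2)c2c1C=CC(C)(C)O2`: compound 2 gives 2250 nM
- compound 3, `COc1ccc(C(=O)/C=C/c2ccc([N+](=O)[O-])cc2)c2c1C=CC(C)(C)O2`: compound 3 gives 3520 nM

Compound 3 holds the second highest of the three numbers; compound 2 lies within the scatter of it, while compound 1 sits beyond, as the step of a 2.0-fold lower number from compound 1 to compound 3 (0.31 log units; beyond the scatter) shows. Compound 4, `COc1ccc(C(=O)/C=C/c2cccc(O)c2)c2c1C=CC(C)(C)O2`, differs from compound 3 by 3-hydroxyphenyl in place of 4-nitrophenyl on a double-bonded chain carbon bound to a double-bonded chain carbon. Going by the values given here, the only measured step, from compound 1 to compound 3, exchanges one substituent on the aromatic ring and is modest in size; no step exchanges the whole aryl group or introduces a hydroxyl, so it bears on the new change only loosely. Compound 4 is therefore expected to show no step beyond the scatter, with a 1.1-fold higher number from compound 3 to compound 4 (0.06 log units; within the scatter). Compound 4 is estimated at 4000 nM, between 1500 nM and 11000 nM.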

Compound 4, half-maximal inhibitory concentration: > 10000 nM
Compound 4: no number, only a limit (the forecaster's own chance of this, stated with the estimate: 5%); at least 2.5-fold (0.39 log units) between middle value and limit.
By their numbers in this assay, from the lowest: compounds 2 and 3 (each within the scatter of the next); then compound 1. At a limit, above all of these: compound 4.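

Going by these compounds alone, exchanging the whole aryl group at this double-bonded chain carbon, 3-hydroxyphenyl in place of 4-nitrophenyl, gives an at least 2.8-fold higher number from compound 3 to compound 4 (0.45 log units; beyond the scatter), so this position responds to a change that no earlier step covered. In this assay compound 4 has no number, only a limit: the limit of > 10000 nM in this assay, at which 1 of the 4 values shown sits.

The step therefore has a lower bound and no known full size. The compounds shown leave open whether the hydroxyl or the loss of the nitro group accounts for it. A methoxy group or an amine on the same aryl group could separate the two.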